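The compounds below may be only part of what the source reports. "The series", "measured", "known", "first", "only" and "open" are said of these compounds alone.

Compound 1 `CN(C)CCn1cnnc1-c1cc(Oc2ccc(NC(=O)N/N=C/c3ccccc3)cc2F)ccn1`: 1860 nM in a functional assay on A549 cells (Homo sapiens) for cytotoxicity, read by MTT assay, with a stated time of 72 h; on this read-out lower numbers stand for stronger inhibition and higher numbers for weaker inhibition. Compound 2 `CN(C)CCn1cnnc1-c1cc(Oc2ccc(NC(=O)N/N=C/c3cc(Br)c(O)c(Br)c3)cc2F)ccn1`: > 100000 nM in this assay, which is a limit of the assay and not a number (the limit of > 100000 nM in this assay, at which 1 of the 2 values shown sits).

Within the data shown here, the only measured change at this position is an at least 53-fold higher number from compound 1 to compound 2 (1.73 log units; beyond the scatter), and it ends at the limit (the limit of > 100000 nM in this assay, at which 1 of the 2 values shown sits), so compound 2 stands at the weakest end of what was measured. Compound 3 `CN(C)CCn1cnnc1-c1cc(Oc2ccc(NC(=O)N/N=C/c3ccc(O)cc3O)cc2F)ccn1` carries 2,4-dihydroxyphenyl in place of 3,5-dibromo-4-hydroxyphenyl on a carbon with a double bond to nitrogen. That single large step is all that bears on this change, and it ran from phenyl to 3,5-dibromo-4-hydroxyphenyl, not onward from that group, so its direction here is uncertain. Compound 3 is expected at 15000 nM, in the range 2000 nM to 100000 nM. The expected step of an at least 6.6-fold lower number from compound 2 to compound 3 (0.82 log units; beyond the scatter) means a lower number, held with much uncertainty.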

Compound 3, half-maximal inhibitory concentration: 12700 nM
Estimate against measurement, compound 3: 1.2-fold (0.07 log units) above; measured number inside the range.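

Swapping 3,5-dibromo-4-hydroxyphenyl for 2,4-dihydroxyphenyl on this carbon restores part of the lost activity: an at least 7.8-fold lower number from compound 2 to compound 3 (0.89 log units; beyond the scatter). The value for compound 2, > 100000 nM, is a limit of the assay and not a number. The plain phenyl group still does better, with a 6.8-fold higher number from compound 1 to compound 3 (0.83 log units; beyond the scatter), so both substituted rings shown fall behind it, though to different degrees.

On these data alone, whether the bromine atoms or the arrangement of the hydroxyl groups sets this gap remains open, as the two rings differ in both. As far as these compounds go, how a phenyl ring carrying an amine or a carboxylic acid would behave here is also open.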